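The compounds below may be only part of what the source reports. "The series", "measured", "known", "first", "only" and "open" are said of these compounds alone.

Working notes on the series in a functional assay on the whole organism with Rattus norvegicus as the target; on this read-out higher numbers stand for an effect only at larger amounts of compound and lower numbers for an effect already at smaller amounts.

Compound 1 `CCC(C)(C)c1ccc2nc(N)sc2c1` is recorded in this assay only as a limit, > 10 mg/kg, not as a number. Compound 2 `CCCCCCc1ccc2nc(N)sc2c1` gives 7 mg/kg in this assay. Compound 3 `N#CCn1c(=N)sc2cc(OC(F)(F)F)ccc21` gives 3.5 mg/kg in this assay, the lowest of the two numbers shown; the nearest value, that of compound 2, lies within the usual scatter of it, so the two cannot be ranked against each other. The one limit in the set is summarized as the limit of > 10 mg/kg in this assay, at which 1 of the 3 values shown sits.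

Compound 4 `CS(=O)(=O)CCCn1c(=N)sc2cc(OC(F)(F)F)ccc21` is not yet measured in this assay. It differs from compound 3 in one place: 2-(methylsulfonyl)ethyl in place of cyano on a saturated chain carbon bound to an aromatic nitrogen. Among the compounds with values here, nothing in the set speaks to a change of this kind; no measured pair shares it. The expectation is therefore that the step from compound 3 to compound 4 in this assay stays close to the scatter, with a lean toward a larger dose, a 1.3-fold higher number from compound 3 to compound 4 (0.11 log units; within the scatter). For compound 4 the dose for half-maximal effect in this assay is estimated at 4.5 mg/kg, within a range from 1.5 mg/kg to 12 mg/kg.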

Compound 4, dose for half-maximal effect: 5 mg/kg
The estimate for compound 4 lay 1.1-fold (0.05 log units) below the measured number, and the stated range covers the measured number.
By their numbers in this assay, from the lowest: compounds 3, 4 and 2 (each within the scatter of the next). At a limit, above all of these: compound 1.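

In this assay the saturated chain carbon bound to an aromatic nitrogen now has its first measured change: 2-(methylsulfonyl)ethyl in place of cyano gives a 1.4-fold higher number from compound 3 to compound 4 (0.15 log units; within the scatter). At this position, then, a nitrile with its triple bond can give way to a larger open-chain group that carries two double bonds outside aromatic rings, with no difference that can be read on this measure. No measurement in the set bears on the cause of this outcome.

From the compounds shown here alone, whether a chain ending in a primary amine or a carboxylic acid would also stay within the scatter of compound 3 remains open. Also open, going by these compounds, is whether a longer chain carrying the methylsulfonyl group would do so, and whether this change would read the same with another substituent elsewhere on the shared core.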